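A few compounds are considered here, and "the series" means these few. Any claim that something is new, unique, unknown or untested is made for them only; others in the source may bear on it.

Of the compounds shown here, three sharing one core have been measured in an ADME assay for solubility, in simulated intestinal fluid; on this read-out lower numbers stand for lower solubility and higher numbers for higher solubility. Compound 1 `O=C(Cc1ccc2c(c1)B(O)OC2)NS(=O)(=O)C1CC1` gives 700 ug/mL. Compound 2 `O=C(O)c1ccn(-c2ccc3c(c2)B(O)OC3)c1` gives 510 ug/mL, and compound 3 `O=C(Cc1ccc2c(c1)B(O)OC2)NS(=O)(=O)c1ccccc1` gives 900 ug/mL. Among these three, compound 1 stands second highest, and its gaps to the other two are both within the scatter: the nearest is compound 3, the furthest is compound 2, and neither difference counts as a real change. Going by the values given here, the only step between two measured compounds is a 1.3-fold higher number from compound 1 to compound 3 (0.11 log units; within the scatter), so exchanging one group on the sulfonyl sulfur for another left the solubility effectively where it was.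

Compound 4 `CC(C(=O)NS(=O)(=O)C1CC1)c1ccc2c(c1)B(O)OC2` differs from compound 1 in one place: methyl in place of hydrogen on a saturated chain carbon bound to an aromatic carbon and a carbonyl carbon. Among the compounds with values here, no measured step touches this position, so the one step available, from compound 1 to compound 3, bears on it only by showing how little the solubility moved when a group elsewhere in the molecule was swapped. Adding a single carbon is a small change, and with nothing pointing to a shift in either direction, no step beyond the scatter is expected in this assay.

The expected value for compound 4 is therefore 600 ug/mL, estimated to lie between 300 ug/mL and 1000 ug/mL, meaning a step of a 1.2-fold lower number from compound 1 to compound 4 (0.07 log units; within the scatter).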

Compound 4, solubility: > 1000 ug/mL
Compound 4 was reported as a limit; the forecaster's own chance of this, stated with the estimate: 5%; middle value at least 1.6-fold (0.22 log units) away from the limit.
By their numbers in this assay, from the lowest: compounds 2, 1 and 3 (each within the scatter of the next). At a limit, above all of these: compound 4.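

Going by these compounds alone, this is the first measured change at the saturated chain carbon bound to an aromatic carbon and a carbonyl carbon, and in this assay compound 4 is reported only as a limit, > 1000 ug/mL, not as a number. Putting methyl in place of hydrogen on that carbon gives an at least 1.4-fold higher number from compound 1 to compound 4 (0.15 log units; that floor lies within the scatter), so this one added carbon did not bring the number down, while the floor of the step alone cannot show a real rise, and the true size of the step could be small or much larger. How far the reading can go is capped by the assay itself: the limit of > 1000 ug/mL in this assay, at which 1 of the 4 values shown sits.

The compounds shown leave open how an ethyl group, a longer chain, a hydroxyl group or an amine on this same carbon would read, and so whether the result belongs to methyl alone or extends to other groups. They also leave open whether methyl on this carbon would give a similar result with phenyl in place of cyclopropyl on the sulfonyl sulfur.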